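The compounds below may be only part of what the source reports. "The series", "measured", "known", "first", "only" and "open" are said of these compounds alone.

Compound 3 `CC(=O)Nc1cccc2c(-c3cccc(NC(=O)c4ccc(C)c(C)c4)c3)ccnc12` is known in a functional assay on A375P cells (Homo sapiens) for antiproliferative activity, read by MTT assay, with a stated time of 48 h (a higher number here means a weaker inhibitor, a lower number a stronger inhibitor), only as a limit, > 20000 nM. Compound 1 `Cc1ccc(C(=O)Nc2cccc(-c3ccnc4c(N)cccc34)c2)cc1C` likewise reaches only a limit in this assay, > 20000 nM. The step from compound 1 to compound 3, a step that the two limits leave unreadable from compound 1 to compound 3, cannot be read because of the limit of > 20000 nM in this assay, at which 2 of the 3 values shown sit. Compound 2 `Nc1cccc2c(-c3cccc(NC(=O)c4ccc(Cl)c(C(F)(F)F)c4)c3)ccnc12` gives 1400 nM in this assay. Compound 4 `CC(=O)Nc1cccc2c(-c3cccc(NC(=O)c4cc(Cl)cc(C(F)(F)F)c4)c3)ccnc12` carries 3-chloro-5-(trifluoromethyl)phenyl in place of 3,4-dimethylphenyl on a carbonyl carbon. Going by the values given here, no measured step covers this exchange on an acetylated core; compound 2 alone shows that a benzamide bearing chlorine and trifluoromethyl can give 1400 nM. Compound 4 is therefore expected to become a stronger inhibitor than compound 3, by an estimated at least 6.6-fold lower number from compound 3 to compound 4 (0.82 log units; beyond the scatter). The estimate for compound 4 is 3000 nM, with a range from 800 nM to 20000 nM.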

Compound 4, half-maximal inhibitory concentration: 6200 nM
Beside the measured number, compound 4's estimate is 2.1-fold (0.32 log units) below it, within the range that was stated.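

In this assay, going by these compounds alone, placing 3-chloro-5-(trifluoromethyl)phenyl on the carbonyl carbon in place of 3,4-dimethylphenyl gives an at least 3.2-fold lower number from compound 3 to compound 4 (0.50 log units; beyond the scatter), the first readable step among the compounds carrying the acetyl group. The acetyl group therefore does not by itself keep a compound at the limit. Going by these compounds, compound 3 stands only at a limit, > 20000 nM, so the step's full size stays open.

Compound 2 and compound 4 differ in more than one place, which leaves the effect of acetyl with a halogenated benzamide unresolved. On these data alone, how a propionyl or methanesulfonyl group on that nitrogen would read also remains open.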